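Combining Chloro and Trifluoromethyl on the Aryl Urea

The compounds below may be only part of what the source reports. "The series", "measured", "known", "first", "only" and "open" are said of these compounds alone.

Of the compounds shown here, three sharing one core have been measured in a functional assay on T47D cells (Homo sapiens) for antiproliferative activity, read by MTT assay, with a stated time of 48 h; a lower number here means a stronger inhibitor, a higher number a weaker inhibitor. Compound 1 `O=C(Nc1cccc(C(F)(F)F)c1)Nc1nnc(Sc2ncnc3scc(-c4ccncc4)c23)s1` gives 45100 nM, compound 2 `Cc1ccc(NC(=O)Nc2nnc(Sc3ncnc4scc(-c5ccncc5)c34)s2)cc1Cl` gives 34800 nM, and compound 3 `Cc1ccc(NC(=O)Nc2nnc(Sc3ncnc4scc(-c5ccncc5)c34)s2)cc1` gives 17800 nM. Compound 3 sits at the low end of these numbers: its gap to compound 1 is beyond the scatter, while its gap to compound 2 is within it.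

Compound 4 `O=C(Nc1ccc(Cl)c(C(F)(F)F)c1)Nc1nnc(Sc2ncnc3scc(-c4ccncc4)c23)s1` is reached from compound 3 by one change: 4-chloro-3-(trifluoromethyl)phenyl in place of 4-methylphenyl on an amide-type nitrogen. Going by the values given here, two measured steps bear on this. Going from a trifluoromethyl-bearing phenyl to a methyl-bearing one, a 2.5-fold lower number from compound 1 to compound 3 (0.40 log units; beyond the scatter). Removing a chloro from the ring, a 2.0-fold lower number from compound 2 to compound 3 (0.29 log units; within the scatter). Compound 4 reverses both directions at once, taking away the methyl and bringing in both a chloro and a trifluoromethyl. In this assay, a higher number for compound 4 than for compound 3 is therefore expected, likely landing near or above compound 1, which carries the trifluoromethyl alone.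

The expected step is a 2.8-fold higher number from compound 3 to compound 4 (0.45 log units; beyond the scatter). For compound 4 the estimate in this assay is 50000 nM, with a range from 20000 nM to 120000 nM.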

Compound 4, half-maximal inhibitory concentration: 28000 nM
Compound 4: the middle estimate sits 1.8-fold (0.25 log units) above what was measured; the range from low to high includes it.
By their numbers in this assay, from the lowest: compounds 3, 4, 2 and 1 (each within the scatter of the next, the first and the last beyond it).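

In this assay, putting 4-chloro-3-(trifluoromethyl)phenyl on the amide-type nitrogen gives a 1.6-fold higher number from compound 3 to compound 4 (0.20 log units; within the scatter) and a 1.2-fold lower number from compound 2 to compound 4 (0.09 log units; within the scatter), so compound 4 cannot be told apart from either methyl-bearing compound. Adding a chloro to the trifluoromethyl-bearing ring gives a 1.6-fold lower number from compound 1 to compound 4 (0.21 log units; within the scatter), which is also too small a step to read on its own. Read as a pair, however, exchanging chloro and hydrogen does not do the same thing on the methyl-bearing ring as on the trifluoromethyl-bearing ring: the same change on two cores in this assay, a 2.0-fold lower number (0.29 log units; within the scatter) from compound 2 to compound 3 and a 1.6-fold higher number (0.21 log units; within the scatter) from compound 4 to compound 1, 3.1-fold (0.50 log units) apart, beyond the scatter of two such steps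

The compounds shown leave open how a phenyl carrying chloro alone would compare, which would help separate the share of the chloro from that of the trifluoromethyl. Also open, from the compounds shown here alone, is how a methoxy group or an amine on this ring, or a longer chain in place of the ring, would read in this assay.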